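The source may hold more compounds than are shown below. What is called first, only, known or untested is meant among the compounds shown, and "the series" means these compounds.

The measured compounds:
compound 1, `CN(c1cc2ncc(=O)[nH]c2cc1NC(=S)NC(=O)c1cccc(C(F)(F)F)c1)C1CCCCC1`: 31500 nM
compound 2, `CN(c1cc2ncc(=O)[nH]c2cc1NC(=S)NC(=O)c1cccc2ccccc12)C1CCCCC1`: 9980 nM
compound 3, `CN(c1cc2ncc(=O)[nH]c2cc1NC(=S)NC(=O)c1ccco1)C1CCCCC1`: 17300 nM

In an ADME assay on Huh-7 cells (Homo sapiens) for cytotoxicity (a lower number here means a stronger inhibitor, a higher number a weaker inhibitor), the three compounds sit close together. Compound 3 gives 17300 nM, the second highest of the three numbers; its nearest neighbour is compound 2, and the step of a 1.7-fold higher number from compound 2 to compound 3 (0.24 log units; within the scatter) lies within the scatter, as does the step of a 1.8-fold lower number from compound 1 to compound 3 (0.26 log units; within the scatter) to the furthest value, that of compound 1. Compound 4, `CN(c1cc2ncc(=O)[nH]c2cc1NC(=S)Nc1cccc2ccccc12)C1CCCCC1`, is compound 3 with naphthalen-1-yl in place of (furan-2-yl)carbonyl on an amide-type nitrogen. Among the compounds with values here, two measured steps bear on this. Within the data shown here, the step of a 1.7-fold higher number from compound 2 to compound 3 (0.24 log units; within the scatter) shows that exchanging furan-2-yl and naphthalen-1-yl on the carbonyl carbon changes little, while a 3.2-fold lower number from compound 1 to compound 2 (0.50 log units; beyond the scatter) is the only step beyond the scatter. Among the measured compounds shown here, compound 4 carries naphthalen-1-yl but no carbonyl, and no measured pair removes the carbonyl, so that part of the change has no precedent here. Because compound 2 gives 9980 nM, compound 4 is expected to land nearby, with a step of a 1.4-fold lower number from compound 3 to compound 4 (0.16 log units; within the scatter) that may well stay within the scatter. The estimate for compound 4 in this assay is 12000 nM, in a range from 4000 nM to 36000 nM.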

Compound 4, half-maximal inhibitory concentration: 43600 nM
Compound 4: the middle estimate sits 3.6-fold (0.56 log units) below what was measured, and the stated range ends below it.
By their numbers in this assay, from the lowest: compounds 2, 3, 1 and 4 (each within the scatter of the next, the first and the last beyond it).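

Earlier steps changed only the group on the carbonyl carbon, whereas this one replaces the whole (furan-2-yl)carbonyl on the amide-type nitrogen with naphthalen-1-yl, and in this assay it gives a 2.5-fold higher number from compound 3 to compound 4 (0.40 log units; beyond the scatter), a step beyond the scatter. The naphthalen-1-yl group therefore does not bring the same number wherever it sits: compound 2, with the carbonyl, gives 9980 nM, and compound 4, without it, gives 43600 nM, a gap printed as beyond the scatter. No measurement shown here explains this difference. The compounds shown leave open how a small chain such as methyl or ethyl, or an acetyl group, would read on this nitrogen. They also leave open whether furan-2-yl attached directly there would behave as naphthalen-1-yl does.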